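The source may report more compounds than this note shows. Statements on the series, on what has been measured and on what is new or still open speak of the compounds shown alone.

Measured so far in an assay on Prostate gland for inhibition of steroid 5-alpha-reductase (Rattus norvegicus); on this read-out higher numbers stand for weaker inhibition and lower numbers for stronger inhibition:
compound 1 `C/C(=C\C(=O)Nc1ccccc1OCCCC(=O)O)c1ccc2c(ccn2C)c1` — 780 nM
compound 2 `CCCCCn1ccc2cc(/C(C)=C/C(=O)Nc3ccccc3OCCCC(=O)O)ccc21` — 23 nM
compound 3 `CCCC(C(C)C)n1ccc2cc(/C(C)=C/C(=O)Nc3ccccc3OCCCC(=O)O)ccc21` — 7.2 nM

Compound 3 gives the lowest number of the three in this assay; the nearest is a 3.2-fold lower number from compound 2 to compound 3 (0.50 log units; beyond the scatter), the furthest a 110-fold lower number from compound 1 to compound 3 (2.03 log units; beyond the scatter). Compound 4 `C/C(=C\C(=O)Nc1ccccc1OCCCC(=O)O)c1ccc2c(ccn2Cc2ccccc2C)c1` differs from compound 3 by 2-methylbenzyl in place of 1-isopropylbutyl on an aromatic nitrogen. All three measured steps bear on this position: a 34-fold lower number from compound 1 to compound 2 (1.53 log units; beyond the scatter) and a 110-fold lower number from compound 1 to compound 3 (2.03 log units; beyond the scatter) are large, a 3.2-fold lower number from compound 2 to compound 3 (0.50 log units; beyond the scatter) is modest. Larger groups on this nitrogen gave lower numbers; 2-methylbenzyl is comparable in size to 1-isopropylbutyl but contains a ring, for which no measured step exists. A number near compound 3 or compound 2 is expected in this assay. The step is estimated as a 2.1-fold higher number from compound 3 to compound 4 (0.32 log units; beyond the scatter). Compound 4 is expected to give 15 nM, range 4 nM to 60 nM.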

Compound 4, half-maximal inhibitory concentration: 69 nM
Estimate against measurement, compound 4: 4.6-fold (0.66 log units) below, and the stated range ends below it.
By their numbers in this assay, from the lowest: compound 3; then compound 2; then compound 4; then compound 1.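

Size alone does not order the numbers on this aromatic nitrogen in this assay: 2-methylbenzyl is the largest group here, yet it gives a 9.6-fold higher number from compound 3 to compound 4 (0.98 log units; beyond the scatter) and a 3.0-fold higher number from compound 2 to compound 4 (0.48 log units; beyond the scatter), so compound 4 goes against the earlier trend of larger groups giving lower numbers. It still gives an 11-fold lower number from compound 1 to compound 4 (1.05 log units; beyond the scatter), so the larger group keeps much of the gain over methyl. No evidence is available to explain the loss against the open-chain groups.

From the compounds shown here alone, whether the ring or its methyl goes with the higher number remains open. Benzyl and cyclohexylmethyl on this nitrogen would help separate the two.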